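Swapping the amide-bearing side chain on a shared core

This account rests on a few compounds, and the source may have more. Where it says the series, first, only, none or still open, it means among the compounds named here.

Of the compounds shown here, three built on one core have been tested in an ADME assay on L6 cells (Rattus norvegicus) for cytotoxicity, read by fluorescence, with a stated time of 72 h; on this read-out higher numbers stand for weaker inhibition and lower numbers for stronger inhibition. Compound 1 `CCN(CC)C(=O)CNC1CC2(N3CCN(C)CC3)CC(c3ccccc3)C1C(c1ccccc1)C2` gives 37900 nM, compound 2 `CN1CCN(C23CC(NCCC(=O)N4CCCC4)C(C(c4ccccc4)C2)C(c2ccccc2)C3)CC1` gives 21500 nM, and compound 3 `CN1CCN(C23CCN(CCCN4CCCC4)C(C(c4ccccc4)C2)C(c2ccccc2)C3)CC1` gives 43500 nM. For the measured compounds named here, the only single-point step measured, a 1.8-fold lower number from compound 1 to compound 2 (0.25 log units; within the scatter), is small. Compound 2 has the lowest number of the three, within the scatter of compound 1 but beyond it from compound 3. Compound 4 `CCN(CC)CC(=O)NC1CC2(N3CCN(C)CC3)CC(c3ccccc3)C1C(c1ccccc1)C2` differs from compound 2 by ((diethylamino)methyl)carbonyl in place of 2-((pyrrolidin-1-yl)carbonyl)ethyl on an amine nitrogen. Going by the values given here, only the step from compound 1 to compound 2 bears on this change, as it too reworked the amide-bearing chain. The step expected in this assay is therefore small, a 1.2-fold higher number from compound 2 to compound 4 (0.08 log units; within the scatter), because a 1.8-fold lower number from compound 1 to compound 2 (0.25 log units; within the scatter) stayed within the scatter. Compound 4 is estimated at 26000 nM, ranging from 11000 nM to 60000 nM.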

Compound 4, half-maximal inhibitory concentration: 26400 nM
Compound 4: middle estimate off by 1.0-fold (0.01 log units), on the low side, and the stated range covers the measured number.
By their numbers in this assay, from the lowest: compounds 2, 4, 1 and 3 (each within the scatter of the next, the first and the last beyond it).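

The ((diethylamino)methyl)carbonyl group on this amine nitrogen gives a 1.2-fold higher number from compound 2 to compound 4 (0.09 log units; within the scatter) when it replaces 2-((pyrrolidin-1-yl)carbonyl)ethyl, and a 1.4-fold lower number from compound 1 to compound 4 (0.16 log units; within the scatter) when it replaces (diethylcarbamoyl)methyl. So, across these compounds, the side chain can lose its five-membered ring, or have its carbonyl moved along the chain, and the number still stays within the scatter. Going by these compounds, whether a carboxylic acid or a much longer chain on this nitrogen would carry the number beyond the scatter remains open. Nothing available explains why these changes leave the number so little altered.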